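From benzyl to (pyridin-2-yl)methyl on the shared core

The compounds below may be only part of what the source reports. "The series", "measured", "known", "first", "only" and "open" are said of these compounds alone.

Compound 1 `CS(=O)(=O)Nc1ccc2c(c1)S(=O)(=O)N=C(c1c(O)c(-c3cccs3)nn(CCC3CCCC3)c1=O)N2` gives > 1 h in an in vitro ADME assay on microsomes from liver (Homo sapiens) for metabolic stability, tested at 5 uM (on this read-out higher numbers stand for a longer-lived compound and lower numbers for a shorter-lived compound), which is a limit of the assay and not a number. Compound 2 `CS(=O)(=O)Nc1ccc2c(c1)S(=O)(=O)N=C(c1c(O)c(-c3cccs3)nn(Cc3ccccc3)c1=O)N2` gives > 1 h in this assay, again only a limit. Its place in the series is therefore known only as the limit of > 1 h in this assay, at which 2 of the 2 values shown sit. Compound 3 `CS(=O)(=O)Nc1ccc2c(c1)S(=O)(=O)N=C(c1c(O)c(-c3cccs3)nn(Cc3ccccn3)c1=O)N2` carries pyridin-2-yl in place of phenyl on a saturated chain carbon bound to an aromatic nitrogen. Among the measured compounds shown here, the only measured step that bears on this change is a step that the two limits leave unreadable from compound 1 to compound 2, so no size can be carried over from it. No step beyond the scatter is expected in this assay, in either direction, although the data cannot exclude one. The expected change is a step that the limit leaves unreadable from compound 2 to compound 3, an estimate that rests on a limit. For compound 3 the estimated half-life is 1.5 h, with an expected range from 0.7 h to 4 h.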

Compound 3, half-life: > 1 h
Compound 3: only a limit was reported; the forecaster's own chance of this, stated with the estimate: 70%; the middle value does not contradict the limit.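

No step can be read from compound 2 to compound 3 or from compound 1 to compound 3 in this assay, as all these values are limits and not numbers: the limit of > 1 h in this assay, at which 3 of the 3 values shown sit.

On these data alone, the actual half-lives of compound 1, compound 2 and compound 3 remain open, as does any difference between benzyl and (pyridin-2-yl)methyl on the shared core.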